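The source may report more compounds than this note shows. Statements on the series, on what has been measured and on what is new or still open speak of the compounds shown alone.

Compound 1 `Cc1ccc2c(c1C)C(=O)N(Cc1cc(Br)ccc1NC(=O)c1ccccn1)C2=O` gives, in an assay on CHO cells for positive allosteric modulation of metabotropic glutamate receptor 5 (Homo sapiens), read by FLIPR (on this read-out lower numbers stand for an effect already at smaller amounts and higher numbers for an effect only at larger amounts of compound), a result at the limit of the assay, > 100000 nM. Compound 2 `Cc1ccc2c(c1C)C(=O)N(Cc1cc(Cl)ccc1NC(=O)c1ccccn1)C2=O` gives 2200 nM. Compound 3 `CCOc1cccc2c1C(=O)N(Cc1cc(Cl)ccc1NC(=O)c1ccccn1)C2=O` gives 280 nM.

Compounds 1 and 2 share one core and differ by bromo in place of chloro on an aromatic carbon; this change brings an at least 45-fold higher number from compound 2 to compound 1 (1.65 log units; beyond the scatter), and the number for compound 1 is the limit (the limit of > 100000 nM in this assay, at which 1 of the 3 values shown sits). Compound 3 carries a different core; the difference between the two cores is not broken down here. Compound 4 `CCOc1cccc2c1C(=O)N(Cc1cc(Br)ccc1NC(=O)c1ccccn1)C2=O` differs from compound 3 by bromo in place of chloro on an aromatic carbon, the same change as that from compound 2 to compound 1. The same change is therefore expected to give a step of a 110-fold higher number from compound 3 to compound 4 (2.03 log units; beyond the scatter), which rests on an at least 45-fold higher number from compound 2 to compound 1 (1.65 log units; beyond the scatter). Compound 4 is estimated at 30000 nM, from 5000 nM to 100000 nM, with a fair chance that only a limit is reported.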

Compound 4, half-maximal effective concentration: 720 nM
Beside the measured number, compound 4's estimate is 42-fold (1.62 log units) above it; the whole stated range lies above it.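

In this assay, bromo in place of chloro gives a 2.6-fold higher number from compound 3 to compound 4 (0.41 log units; beyond the scatter), so the number rises on both cores, but the size of the step does not carry over from one core to the other: the same change on two cores in this assay, an at least 45-fold higher number (1.65 log units; beyond the scatter) from compound 2 to compound 1 and a 2.6-fold higher number (0.41 log units; beyond the scatter) from compound 3 to compound 4, at least 17-fold (1.24 log units) apart, beyond the scatter of two such steps. The earlier step has no exact size, as compound 1 gives a limit and not a number: the limit of > 100000 nM in this assay, at which 1 of the 4 values shown sits. For the compounds shown here, with only two cores, this shows that the direction was shared here, but not how large the step would be on a further core or what sets the difference.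

The compounds shown leave open how fluoro, methyl or methoxy would behave in place of chloro on each core. They also leave open whether a core carrying a longer chain than the ethoxy group of compound 3 would give a step nearer the earlier or the later one.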